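From phenyl to pyridin-3-yl in a cytotoxicity series

A few compounds are considered here, and "the series" means these few. Any claim that something is new, unique, unknown or untested is made for them only; others in the source may bear on it.

Measured so far in a functional assay on MDBK cells (Bos taurus) for cytotoxicity; a higher number here means that more compound is tolerated, a lower number that less compound is tolerated:
- Compound 1 (`CO/N=C(\C#N)C(=O)NCC1=NOC(C(C)(C)C)C1`): > 100 ug/mL
- Compound 2 (`C=CCO/N=C(\C#N)C(=O)NCC1=NOC(C(C)(C)C)C1`): > 100 ug/mL
- Compound 3 (`CC(C)(C)C1CC(CNC(=O)/C(C#N)=N/OCc2ccccc2)=NO1`): 100 ug/mL

The entry for compound 1, > 100 ug/mL, is a limit of the assay and not a number. The entry for compound 2, > 100 ug/mL, is a limit as well. Going by the values given here, compound 3, at 100 ug/mL, holds the only actual number among the three.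

Compound 4 (`CC(C)(C)C1CC(CNC(=O)/C(C#N)=N/OCc2cccnc2)=NO1`) differs from compound 3 in a single place: pyridin-3-yl in place of phenyl on a saturated chain carbon bound to an oxygen. In words, pyridin-3-yl takes the place of phenyl on a saturated chain carbon bound to an oxygen.

Two measured steps change the group at this same place: a number no higher from compound 1 to compound 3 (the limit leaves the size open) and a number no higher from compound 2 to compound 3 (the limit leaves the size open). The size of neither can be read, and neither brings in pyridin-3-yl. They therefore give no reason to predict a move in either direction. The expected change is no change at the digits printed from compound 3 to compound 4 (within the scatter), which means no step beyond the usual scatter is expected in this assay. For compound 4 the estimated value is 100 ug/mL, with an expected range of 50 ug/mL to 200 ug/mL.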

Compound 4, half-maximal cytotoxic concentration: > 100 ug/mL
Compound 4 ended at the assay's limit (the forecaster's own chance of this, stated with the estimate: 60%); the middle value lies on the limit itself.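

Putting pyridin-3-yl in place of phenyl on a saturated chain carbon bound to an oxygen gives, in this assay, a number no lower from compound 3 to compound 4 (the limit leaves the size open). The earlier steps shown here at this place could not show this, since none of them brought in a ring with a hetero atom: here one ring carbon gives way to a nitrogen, adding one hydrogen-bond acceptor, and the number does not fall. The entry for compound 4 is a limit of the assay and not a number, and neither the size of this step nor the steps to compound 4 from compound 1 and compound 2 can be read, with the values gathered at a single ceiling: the limit of > 100 ug/mL in this assay, at which 3 of the 4 values shown sit.

Still open, on these data alone, is whether pyridin-2-yl or pyridin-4-yl at this place, or a phenyl carrying an amine or a carboxylic acid, would stay at that limit or give a lower number. The compounds shown also cover only tolerance in this assay, so how this change behaves in any other test remains unknown.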